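Compound 2 to Compound 4: Replacing 3-Methoxyphenyl with 3,5-Dimethylphenyl

The source may hold more compounds than are shown below. What is called first, only, known or untested is meant among the compounds shown, and "the series" means these compounds.

Of the compounds shown here, three have been tested so far in an ADME assay on HEK-293T cells (Homo sapiens) for cytotoxicity, read by CCK-8 assay, with a stated time of 48 h (a higher number here means a weaker inhibitor, a lower number a stronger inhibitor), and none has given an exact number. Compound 1 `O=S(=O)(NCCNC(=S)Nc1cc(C(F)(F)F)cc(C(F)(F)F)c1)c1cc(-c2ccccc2Oc2ccc(O)c(O)c2)cs1` gives > 20000 nM as its result, which is a limit and not a number. Compound 2 `COc1cccc(NC(=O)NCCNS(=O)(=O)c2ccc(-c3ccccc3OCc3ccccc3)s2)c1` gives > 20000 nM as its result, also a limit. Compound 3 `O=S(=O)(NCCNC(=S)Nc1cc(C(F)(F)F)cc(C(F)(F)F)c1)c1ccc(-c2ccccc2O[C@H]2CC[C@@H](O)CC2)s1` gives > 20000 nM as its result, again a limit. The record so far is therefore the limit of > 20000 nM in this assay, at which 3 of the 3 values shown sit, and compound 2 stands at that limit, with no exact position of its own.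

Compound 4 `Cc1cc(C)cc(NC(=O)NCCNS(=O)(=O)c2ccc(-c3ccccc3OCc3ccccc3)s2)c1` differs from compound 2 in one place 3,5-dimethylphenyl in place of 3-methoxyphenyl on an amide-type nitrogen with 3,5-dimethylphenyl in place of 3-methoxyphenyl on an amide-type nitrogen. Among the measured compounds shown here, no pair of tested compounds differs in just one place, so there is no measured step to use as a guide. Since compound 2 sits at the limit of > 20000 nM in this assay the expectation is no step beyond the usual scatter, in neither direction, and another report of a limit is the likeliest result. The estimated change is a step that the limit leaves unreadable from compound 2 to compound 4 and it is small. For compound 4 the estimated value is 25000 nM with 12000 nM to 50000 nM as its expected range.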

Compound 4, half-maximal inhibitory concentration: > 20000 nM
Compound 4 gave a limit, no number; the forecaster's own chance of this, stated with the estimate: 75%; the middle value lies beyond the limit too.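

Among the compounds shown here, compound 2 and compound 4 each give only a limit in this assay, and no step between them can be read. The compounds shown leave open what exact value any of them would give, and whether 3,5-dimethylphenyl in place of 3-methoxyphenyl makes any difference to the result at all.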